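Aryl swap on the aromatic nitrogen: compound 2 to compound 3

The source may hold more compounds than are shown below. What is called first, only, known or untested is meant among the compounds shown, and "the series" means these compounds.

Compound 1 `Cc1ccccc1-n1nncc1CN1C(=O)C2(C(C#N)=C(N)Oc3c(N)cc4nc5ccccc5nc4c32)c2ccccc21` carries a 2-methylphenyl on an aromatic nitrogen of the shared core. In a functional assay on A549 cells (Homo sapiens) for antiproliferative activity, read by MTT assay, with a stated time of 48 h (on this read-out higher numbers stand for weaker inhibition and lower numbers for stronger inhibition), compound 1 gives 31700 nM. Compound 2 `N#CC1=C(N)Oc2c(N)cc3nc4ccccc4nc3c2C12C(=O)N(Cc1cnnn1-c1ccc(Cl)cc1Cl)c1ccccc12` differs by a 2,4-dichlorophenyl in place of that 2-methylphenyl. In this assay compound 2 reaches only a limit of the assay, > 50000 nM. The step of an at least 1.5-fold higher number from compound 1 to compound 2 (0.19 log units; that floor lies within the scatter) is thus known only as a floor. That floor rests on (the limit of > 50000 nM in this assay, at which 1 of the 2 values shown sits). Compound 3 `COc1ccc(OC)c(-n2nncc2CN2C(=O)C3(C(C#N)=C(N)Oc4c(N)cc5nc6ccccc6nc5c43)c3ccccc32)c1` is not yet measured and changes the same aryl group: 2,5-dimethoxyphenyl in place of 2,4-dichlorophenyl on an aromatic nitrogen. Going by the values given here, no measured step brings in a dimethoxyphenyl, so the single aryl swap already in hand is the only guide, and both aryl variants show weak inhibition. Compound 3 is therefore expected to stay weak, with the step of an at least 1.1-fold lower number from compound 2 to compound 3 (0.04 log units; that floor lies within the scatter) not beyond the scatter. Compound 3 is estimated at 45000 nM, between 20000 nM and 100000 nM, with a fair chance of again only a limit.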

Compound 3, half-maximal inhibitory concentration: 28100 nM
Compound 3: the middle estimate sits 1.6-fold (0.20 log units) above what was measured; the range from low to high includes it.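

In this assay the 2,5-dimethoxyphenyl gives this aromatic nitrogen a second exact value, and the step of a 1.1-fold lower number from compound 1 to compound 3 (0.05 log units; within the scatter) leaves it indistinguishable from 2-methylphenyl. On this evidence, a phenyl carrying 2 hydrogen-bond acceptors does not separate from the 2-methylphenyl of compound 1 in this read-out. Compound 2 stands only at a limit of the assay, so the step of an at least 1.7-fold lower number from compound 2 to compound 3 (0.25 log units; that floor lies within the scatter) is a floor that does not separate 2,5-dimethoxyphenyl from 2,4-dichlorophenyl, and it rests on that limit: the limit of > 50000 nM in this assay, at which 1 of the 3 values shown sits.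

As far as these compounds go, the true distance between the 2,4-dichlorophenyl and 2,5-dimethoxyphenyl compounds stays open. Also open, from the compounds shown here alone, is whether a phenyl bearing an amine or a carboxylic acid, or a benzyl on this nitrogen, would lower the number beyond the scatter.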